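Solubility at Low pH Across a Shared Core

The source may hold more compounds than are shown below. What is called first, only, known or untested is meant among the compounds shown, and "the series" means these compounds.

Compound 1 `CNc1nc(NCCCN(C)C)c2sc(-c3ccc(S(C)(=O)=O)cc3)cc2n1` was examined in a physicochemical assay for solubility, at pH 2; a lower number here means a less soluble compound, a higher number a more soluble compound. In this assay compound 1 gives > 100 ug/mL, which is a limit of the assay rather than a number. Compound 2 `CNc1nc(NCCCN(C)C)c2sc(-c3cccc(C#N)c3)cc2n1` shares the same core and carries a nitrile in place of the methylsulfonyl. In this assay compound 2 gives > 100 ug/mL, again a limit and not a number. Among the measured compounds shown here, both values sit at the limit of > 100 ug/mL in this assay, at which 2 of the 2 values shown sit, so compound 1 stands at the edge of what this assay reports, alongside compound 2, and no step between the two can be sized.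

Compound 3 `CNc1nc(NCCCN(C)C)c2sc(-c3ccc(N4CCNCC4)cc3)cc2n1` is not yet measured. It differs from compound 1 in one place: piperazin-1-yl in place of methylsulfonyl on an aromatic carbon. For the measured compounds named here, with no measured step to lean on, the expected change is estimated as none beyond the scatter, namely a step that the limit leaves unreadable from compound 1 to compound 3. Compound 3 is accordingly expected to give about 300 ug/mL, between 100 ug/mL and 1000 ug/mL, most likely reported once more as a limit.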

Compound 3, solubility: > 100 ug/mL
Compound 3 was reported as a limit (the forecaster's own chance of this, stated with the estimate: 90%); the middle value does not contradict the limit.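

Among the compounds shown here, compound 3, like compound 1, stands at a limit of this assay and not at a number, so no step between the two can be read: the limit of > 100 ug/mL in this assay, at which 3 of the 3 values shown sit.

The compounds shown leave open how the three compare in this assay, and whether any change to the shared core gives a value that is a number.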